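Adding a Methoxy Group: From Compound 2 to Compound 3

This account rests on a few compounds, and the source may have more. Where it says the series, first, only, none or still open, it means among the compounds named here.

Measured compounds:
Compound 1 `Nc1cc(N)c2nc(-c3ccccc3)c(NCc3ccc(Cl)c(Cl)c3)nc2c1`: 3390 nM
Compound 2 `COc1ccc(CNc2nc3cc(N)cc(N)c3nc2-c2ccccc2)cc1OC`: 6760 nM

In a functional assay on OVCAR-8 cells (Homo sapiens) for inhibition, read by sulforhodamine B assay, with a stated time of 48 h (a higher number here means a weaker inhibitor of growth, a lower number a stronger inhibitor of growth), compound 1 gives 3390 nM and compound 2 gives 6760 nM. Within the data shown here, compound 2 has the highest of the two numbers, but its only neighbour is compound 1, and the step from compound 1 to compound 2 is a 2.0-fold higher number from compound 1 to compound 2 (0.30 log units; within the scatter), so the two values cannot be told apart.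

Compound 3 `COc1cc(CNc2nc3cc(N)cc(N)c3nc2-c2ccccc2)cc(OC)c1OC` has not yet been measured. It differs from compound 2 in one place: methoxy in place of hydrogen on an aromatic carbon. The methoxy enters on an aromatic carbon of a six-membered aromatic ring of carbon only, ortho to a methoxy group, meta to a large group and meta to a methoxy group.

Among the measured compounds shown here, the only measured step that bears on this change is the one from compound 1 to compound 2, which is a 2.0-fold higher number from compound 1 to compound 2 (0.30 log units; within the scatter). That step also altered the substituents of this same ring without moving the number beyond the scatter. On that basis, the step from compound 2 to compound 3 in this assay is expected to be a 1.0-fold higher number from compound 2 to compound 3 (0.02 log units; within the scatter), with no clear direction. Compound 3 is therefore estimated at 7000 nM, in a range from 2500 nM to 20000 nM.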

Compound 3, concentration for 50% growth inhibition: 6920 nM
For compound 3 the middle estimate is 1.0-fold (0.00 log units) above the measured one; the range from low to high includes it.
By their numbers in this assay, from the lowest: compounds 1, 2 and 3 (each within the scatter of the next, the first and the last beyond it).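

The step for this change in this assay reads a 1.0-fold higher number from compound 2 to compound 3 (0.01 log units; within the scatter), so compound 2 and compound 3 cannot be told apart. Among these compounds, what the earlier compounds did not show is that this ring can carry a further methoxy, on an aromatic carbon ortho to a methoxy group, meta to a large group and meta to a methoxy group, with the number staying within the scatter; this rests on a single pair and holds only for that pair. No measurement at hand accounts for this result or says what the added methoxy does in the cells.

The compounds shown leave open whether this carbon would tolerate groups of another kind, such as an amine, a carboxylic acid or a longer alkoxy chain, since only hydrogen and methoxy are compared there. They also leave open whether a change elsewhere, for instance a different group on the shared core or a longer chain between the nitrogen and this ring, would move the number beyond the scatter.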